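This account rests on a few compounds, and the source may have more. Where it says the series, first, only, none or still open, it means among the compounds named here.

Measured compounds:
compound 1 `COc1ccc2c(c1)C(=O)CCN2c1nc(Cl)nc2ccccc12`, 27 nM
compound 2 `COc1ccc2c(c1)C(=O)CCN2c1nc(C)nc2ccccc12`, 24 nM
compound 3 `COc1ccc2c(c1)CCCN(c1nc(Cl)nc3ccccc13)C2`, 7570 nM

In a functional assay on A549 cells (Homo sapiens) for cytotoxicity, read by sulforhodamine B assay (on this read-out higher numbers stand for weaker inhibition of growth and lower numbers for stronger inhibition of growth), compound 1 gives 27 nM and compound 2 gives 24 nM. The change from compound 1 to compound 2 is methyl in place of chloro on an aromatic carbon. The step it made is a 1.1-fold lower number from compound 1 to compound 2 (0.05 log units; within the scatter).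

Compound 3 rests on a different core; the difference between the two cores is not broken down here. In this assay compound 3 gives 7570 nM, the highest of the three numbers, with gaps to compound 1 and compound 2 that lie beyond the scatter.

Compound 4 `COc1ccc2c(c1)CCCN(c1nc(C)nc3ccccc13)C2` has not yet been measured. It differs from compound 3 by methyl in place of chloro on an aromatic carbon, the same change as that from compound 1 to compound 2. The step expected in this assay is a 1.1-fold lower number from compound 3 to compound 4 (0.03 log units; within the scatter), resting on the measured value of compound 3 and on the earlier step of the same change, a 1.1-fold lower number from compound 1 to compound 2 (0.05 log units; within the scatter), which stayed within the scatter. Compound 4 is accordingly expected to give about 7000 nM, estimated to fall between 2500 nM and 20000 nM.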

Compound 4, concentration for 50% growth inhibition: 16700 nM
Compound 4: middle estimate off by 2.4-fold (0.38 log units), on the low side; low and high end bracket the measured number.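

In this assay, methyl in place of chloro on an aromatic carbon gives a 2.2-fold higher number from compound 3 to compound 4 (0.34 log units; beyond the scatter), a modest step on the core of compound 3. Set beside the same change on the core of compound 1, this step cannot be told apart from the earlier one: the same change on two cores in this assay, a 1.1-fold lower number (0.05 log units; within the scatter) from compound 1 to compound 2 and a 2.2-fold higher number (0.34 log units; beyond the scatter) from compound 3 to compound 4, 2.5-fold (0.39 log units) apart, within the scatter of two such steps. The change therefore shows no measurable dependence on the core across these two pairs, but two pairs do not establish that the cores respond alike, and they give no reason for the size of either step.

Still open, from the compounds shown here alone, is whether other groups in this place between two ring nitrogen atoms, such as an amine or a nitrile, would behave alike on both cores. Also open, going by these compounds, is which part of the difference between the two cores goes with the much higher numbers of compound 3 and compound 4.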